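The source may hold more compounds than are shown below. What is called first, only, known or untested is meant among the compounds shown, and "the series" means these compounds.

Series so far, in a functional assay on SEM cells (Homo sapiens) for inhibition, read by MTT assay, with a stated time of 72 h; on this read-out lower numbers stand for stronger inhibition and higher numbers for weaker inhibition:
- compound 1 `C=C(Br)C(=O)Nc1cccc(/C=C/C(=O)Nc2ccc(F)c(F)c2)c1`: 90 nM
- compound 2 `C=C(Br)C(=O)Nc1cccc(/C=C/C(=O)Nc2ccc(Cl)cc2)c1`: 1190 nM

Not yet measured: compound 3 `C=C(Br)C(=O)Nc1cccc(/C=C/C(=O)Nc2ccc(OC)cc2)c1`.

Of the two numbers in hand, compound 2 holds the higher, 1190 nM, so it is the weaker of the pair. The next change is methoxy in place of chloro on an aromatic carbon, para to a large group. Among the measured compounds shown here, only one measured step bears on this, a 13-fold higher number from compound 1 to compound 2 (1.12 log units; beyond the scatter). It is large and beyond the scatter, and it concerns the same group on the amide-type nitrogen, 4-chlorophenyl in place of 3,4-difluorophenyl. For the measured compounds named here, that single pair shows that the number in this assay can move far when this group changes, but it gives no direction for chloro to methoxy, since no measured pair makes that exchange. The central expectation is therefore no clear shift, with a wide margin either way. The estimated step is a 1.2-fold lower number from compound 2 to compound 3 (0.08 log units; within the scatter). For compound 3 the estimated value is 1000 nM, with an expected range of 280 nM to 3500 nM.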

Compound 3, half-maximal inhibitory concentration: 70 nM
Compound 3: middle estimate off by 14-fold (1.15 log units), on the high side; the whole stated range lies above it.
By their numbers in this assay, from the lowest: compounds 3 and 1 (each within the scatter of the next); then compound 2.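

In this assay, methoxy in place of chloro on an aromatic carbon, para to a large group, gives a 17-fold lower number from compound 2 to compound 3 (1.23 log units; beyond the scatter) and so shows that this one exchange at this position can carry a large step by itself, with methoxy on the side of stronger inhibition. Among the compounds shown here, the change from 3,4-difluorophenyl to 4-methoxyphenyl gives a 1.3-fold lower number from compound 1 to compound 3 (0.11 log units; within the scatter) and does not separate those two groups, which leaves 4-chlorophenyl as the only group of the three whose steps to both others lie beyond the scatter. Nothing in hand accounts for the gap between chloro and methoxy at this position.

Still open, on these data alone, is whether the lower number is particular to methoxy or extends to other groups at this position, such as hydroxy, an amine, or a longer chain such as ethoxy. An unsubstituted phenyl would also be needed to show whether the chloro group raises the number or the methoxy group lowers it, and these three compounds cannot settle that.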